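The source may report more compounds than this note shows. Statements on the series, on what has been measured and on what is new or still open speak of the compounds shown alone.

Measured in a functional assay on SK-MEL-2 cells (Homo sapiens) for cytotoxicity, read by sulforhodamine B assay, with a stated time of 48 h; a higher number here means a weaker inhibitor of growth, a lower number a stronger inhibitor of growth:
compound 1, `ClCc1ccccc1Cn1cnc2c(Cl)nc(Cl)nc21`, gives 4360 nM.
compound 2, `ClCc1cccc(Cn2cnc3c(Cl)nc(Cl)nc32)c1`, gives 4460 nM.
compound 3, `Nc1nc(Cl)c2ncn(Cc3ccccc3CCl)c2n1`, gives 81300 nM.

Compound 1 and compound 2 are built from the same atoms joined differently; the difference between the two cores is not broken down here. Their numbers in this assay sit close together. Compound 3 is compound 1 with a single change, (amino in place of chloro on an aromatic carbon), and this change gave a 19-fold higher number from compound 1 to compound 3 (1.27 log units; beyond the scatter), a step that left compound 3 a much weaker inhibitor of growth than compound 1.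

Compound 4, `Nc1nc(Cl)c2ncn(Cc3cccc(CCl)c3)c2n1`, has not yet been measured in this assay. It stands to compound 2 as compound 3 stands to compound 1: amino in place of chloro on an aromatic carbon, the same change at a place described in the same words. Within the data shown here, the change has been seen only once, so the expectation rests on the single step of a 19-fold higher number from compound 1 to compound 3 (1.27 log units; beyond the scatter) applied to the value of compound 2, 4460 nM. The expected step is therefore a 19-fold higher number from compound 2 to compound 4 (1.27 log units; beyond the scatter). Compound 4 is estimated at 83000 nM, with a range expected to run from 35000 nM to 200000 nM.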

Compound 4, concentration for total growth inhibition: 66100 nM
Compound 4: middle estimate off by 1.3-fold (0.10 log units), on the high side; low and high end bracket the measured number.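

In this assay, putting amino in place of chloro on the second core gave a 15-fold higher number from compound 2 to compound 4 (1.17 log units; beyond the scatter) and left compound 4 a much weaker inhibitor of growth than compound 2. The size of the step carried over well between these two arrangements of the same atoms, so the result on one core would have predicted the result on the other: the same change on two cores in this assay, a 19-fold higher number (1.27 log units; beyond the scatter) from compound 1 to compound 3 and a 15-fold higher number (1.17 log units; beyond the scatter) from compound 2 to compound 4, 1.3-fold (0.10 log units) apart, within the scatter of two such steps. This shows that the change behaved alike on these two cores in this one assay, but two cores are too few to establish a rule for the wider series, and the numbers do not show why the amino group weakens growth inhibition.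

The compounds shown leave open how other groups on the same aromatic carbon would compare with chloro and amino, for example a methylamino or a methoxy group. They also leave open whether the step would stay the same size if the other chloro group on that ring were replaced by a methyl group.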